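Moving the hydroxyl on a benzothiophene-free anilide series

This account rests on a few compounds, and the source may have more. Where it says the series, first, only, none or still open, it means among the compounds named here.

Measured so far:
- compound 1, `N#Cc1c(Nc2cccc(O)c2)sc2ccccc12`: 60%
- compound 2, `COc1cc2sc(Nc3cccc(O)c3)c(C#N)c2cc1OC`: 67%

Both compounds were tested in a functional assay on HUVEC cells (Homo sapiens), read by fluorescence and microscopy, with a stated time of 6 h, tested at 250 nM; on this read-out higher numbers stand for a weaker effect at the one concentration tested and lower numbers for a stronger effect. On the two numbers shown, compound 2 stands at the top, but compound 1 sits close enough that the gap falls within the usual scatter of repeated measurements, so the two cannot be told apart with confidence. The two compounds differ in more than one place, so nothing can be said about what any single change does.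

Compound 3, `COc1cc2sc(Nc3ccc(O)cc3)c(C#N)c2cc1OC`, has not yet been measured in this assay. It differs from compound 2 only in the group attached to the nitrogen: 4-hydroxyphenyl in place of 3-hydroxyphenyl on a nitrogen on an aromatic ring

For the measured compounds named here, no measured pair in this set shows what moving the hydroxyl group around the ring does, so there is no step on which to rest a direction. The expected step from compound 2 to compound 3 is therefore a number 2 percentage points lower from compound 2 to compound 3 (within the scatter), that is, none beyond the scatter. Compound 3 is estimated at 65%, within a range from 45% to 85%.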

Compound 3, a percentage reported as activity, at one concentration (the size of the read-out at that concentration, not a potency): 73%
For compound 3 the middle estimate is 8 percentage points below the measured one, and the stated range covers the measured number.
By their numbers in this assay, from the lowest: compounds 1, 2 and 3 (each within the scatter of the next, the first and the last beyond it).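

For the compounds shown here, this is the first pair in the set that differs in one place only, so the hydroxyl can now be looked at by itself: in this assay putting 4-hydroxyphenyl in place of 3-hydroxyphenyl on the nitrogen gives a number 6 percentage points higher from compound 2 to compound 3 (within the scatter) and so cannot be told apart from no change at all. The two groups have the same atoms and the same counts of hydrogen-bond donors and acceptors, which means the step tests only where the hydroxyl sits on the ring, and on this single pair that shift makes no difference that stands clear of ordinary repeat-to-repeat variation. Nothing available here offers a measurement that would bear on this result.

As far as these compounds go, whether the hydroxyl matters at all remains open, since a ring carrying an amine or a carboxylic acid in its place would be needed to show what this position tolerates. From the compounds shown here alone, it is also open whether the same move on the core of compound 1 would give a similarly small step, since this one pair rests on the core shared by compound 2 and compound 3 alone.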